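The source may hold more compounds than are shown below. What is called first, only, known or untested is meant among the compounds shown, and "the series" means these compounds.

In a functional assay on HeLa cells (Homo sapiens) for cytotoxicity, read by sulforhodamine B assay (on this read-out lower numbers stand for stronger inhibition and higher numbers for weaker inhibition), compound 1 `Cc1ccc(S(=O)(=O)NC(C2=CC(=O)c3c(O)ccc(O)c3C2=O)C(C)C)cc1` gives 4850 nM, compound 2 `COc1ccc(S(=O)(=O)NC(C2=CC(=O)c3c(O)ccc(O)c3C2=O)C(C)C)c(OC)c1` gives 2750 nM and compound 3 `CC(C)C(NS(=O)(=O)c1ccc(Cl)cc1)C1=CC(=O)c2c(O)ccc(O)c2C1=O` gives 8650 nM. Compound 3 shares the upper end of these numbers with compound 1: a 1.8-fold higher number from compound 1 to compound 3 (0.25 log units; within the scatter) stays within the scatter, while a 3.1-fold higher number from compound 2 to compound 3 (0.50 log units; beyond the scatter) goes beyond it. Compound 4 `CC(C)C(NS(=O)(=O)c1ccc(Br)cc1)C1=CC(=O)c2c(O)ccc(O)c2C1=O` carries bromo in place of chloro on an aromatic carbon, bromo in place of chloro on an aromatic carbon, para to a large group. For the measured compounds named here, no bromo compound has been measured. The nearest evidence is the swap of methyl for chloro at that place, a 1.8-fold higher number from compound 1 to compound 3 (0.25 log units; within the scatter). No change beyond the scatter is therefore expected in this assay. The expected step is a 1.2-fold lower number from compound 3 to compound 4 (0.06 log units; within the scatter). For compound 4 the estimate is 7500 nM, with an expected range of 3200 nM to 16000 nM.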

Compound 4, half-maximal inhibitory concentration: 7650 nM
Compound 4: middle estimate off by 1.0-fold (0.01 log units), on the low side; measured number inside the range.
By their numbers in this assay, from the lowest: compounds 2, 1, 4 and 3 (each within the scatter of the next, the first and the last beyond it).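

At the aromatic carbon para to a large group, in this assay, bromo and chloro do not separate: a 1.1-fold lower number from compound 3 to compound 4 (0.05 log units; within the scatter). Bromo and methyl at that place do not separate either, a 1.6-fold higher number from compound 1 to compound 4 (0.20 log units; within the scatter), while the exchange of 2,4-dimethoxyphenyl for 4-bromophenyl on the sulfonyl sulfur, a 2.8-fold higher number from compound 2 to compound 4 (0.44 log units; beyond the scatter), stays beyond the scatter, as it does for 4-chlorophenyl, a 3.1-fold higher number from compound 2 to compound 3 (0.50 log units; beyond the scatter). No supporting data are available to explain these results.

Going by these compounds, whether an amine or a carboxylic acid at that place would give a step beyond the scatter remains open. Also open, on these data alone, is whether a single methoxy group would match the value of compound 2.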